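The source may hold more compounds than are shown below. What is called first, only, known or untested is meant among the compounds shown, and "the series" means these compounds.

Three compounds share one core and differ only in the aryl group on the urea. In a functional assay on SW-620 cells (Homo sapiens) for inhibition, read by MTT assay, with a stated time of 72 h (on this read-out higher numbers stand for weaker inhibition and lower numbers for stronger inhibition), compound 1 `COc1cc(NC(C)CCCNC(=O)Nc2ccc(F)cc2)c2ncccc2c1` gives 25000 nM, compound 2 `COc1cc(NC(C)CCCNC(=O)Nc2ccc(O)cc2)c2ncccc2c1` gives 30000 nM, and compound 3 `COc1cc(NC(C)CCCNC(=O)Nc2cccc(O)c2)c2ncccc2c1` gives 27000 nM. Compound 2 has the highest of the three numbers, but its neighbours sit close: a 1.1-fold lower number from compound 2 to compound 3 (0.05 log units; within the scatter), and a 1.2-fold higher number from compound 1 to compound 2 (0.08 log units; within the scatter), so the three values cannot be told apart. The third pairing is likewise flat: a 1.1-fold higher number from compound 1 to compound 3 (0.03 log units; within the scatter).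

Compound 4 `COc1cc(NC(C)CCCNC(=O)NNC(=O)Nc2ccc(Cl)cc2)c2ncccc2c1` carries a larger change: ((4-chlorophenyl)carbamoyl)amino in place of 4-hydroxyphenyl on an amide-type nitrogen. Going by the values given here, no measured step shows an extension of this kind on the amide-type nitrogen, so the expectation rests only on how little the aryl changes moved the numbers. Because swapping hydroxy for fluoro gave a 1.2-fold higher number from compound 1 to compound 2 (0.08 log units; within the scatter) and shifting the hydroxy gave a 1.1-fold lower number from compound 2 to compound 3 (0.05 log units; within the scatter), every change so far has stayed inside the scatter, and compound 4 is expected to stay near the same level, with the step of a 1.1-fold lower number from compound 2 to compound 4 (0.03 log units; within the scatter) from compound 2 to compound 4 estimated as no more than the scatter allows. On this basis compound 4 is estimated at 28000 nM in this assay, within a range from 10000 nM to 80000 nM.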

Compound 4, half-maximal inhibitory concentration: 48000 nM
Beside the measured number, compound 4's estimate is 1.7-fold (0.23 log units) below it; the measured number falls inside the stated range.
By their numbers in this assay, from the lowest: compounds 1, 3, 2 and 4 (each within the scatter of the next).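

In this assay, putting ((4-chlorophenyl)carbamoyl)amino on the amide-type nitrogen gives a 1.6-fold higher number from compound 2 to compound 4 (0.20 log units; within the scatter), a 1.8-fold higher number from compound 3 to compound 4 (0.25 log units; within the scatter) and a 1.9-fold higher number from compound 1 to compound 4 (0.28 log units; within the scatter). These steps are larger in size than any among compounds 1, 2 and 3, yet all three stay within the scatter, so the flat picture now holds for a change of the whole group, with 11 heavy atoms entering where 7 leave in the step from compound 2, and not only for a swap on the aromatic ring. No information is available on why this position responds so little to the change.

Going by these compounds alone, the single change in compound 4 brings in the chlorine and the extra carbonyl and nitrogens together, so the share of each in these steps stays open. On these data alone, whether an amine, a carboxylic acid or a longer chain on this amide-type nitrogen would move the number beyond the scatter also remains open, since all four compounds sit within the scatter of one another.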